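The source may report more compounds than this note shows. Statements on the series, on what has been measured and on what is new or still open speak of the compounds shown alone.

Measured compounds:
compound 1 `CCS(=O)(=O)n1cc(-c2nc(Nc3cc(Cl)c(N4CCC(N5CCN(C)CC5)CC4)cc3C)ncc2Cl)c2ccccc21` — 1320 nM
compound 2 `CCOc1cc(N2CCC(N3CCN(C)CC3)CC2)c(Cl)cc1Nc1ncc(Cl)c(-c2cn(S(=O)(=O)CC)c3ccccc23)n1` — 7860 nM

Among the measured compounds shown here, in a toxicity assay on BaF3 cells (Mus musculus) for inhibition, read by CCK-8 assay, with a stated time of 72 h (on this read-out lower numbers stand for stronger inhibition and higher numbers for weaker inhibition), compound 2 stands with the higher of the two numbers, its only neighbour being compound 1, and the single measured step is a 6.0-fold higher number from compound 1 to compound 2 (0.77 log units; beyond the scatter). Compound 3 `CCS(=O)(=O)n1cc(-c2nc(Nc3cc(Cl)c(N4CCC(N5CCN(C)CC5)CC4)cc3OC(C)C)ncc2Cl)c2ccccc21` differs from compound 2 by methyl in place of hydrogen on a saturated chain carbon bound to an oxygen on an aromatic ring and a saturated chain carbon, ethoxy to isopropoxy. That measured step alone bears on it, and it ran to a higher number; a further step of similar direction but smaller size is expected, a 1.5-fold higher number from compound 2 to compound 3 (0.18 log units; within the scatter). Compound 3 is thus expected at 12000 nM, with a range of 4000 nM to 35000 nM.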

Compound 3, half-maximal inhibitory concentration: > 10000 nM
Compound 3 ended at the assay's limit; the forecaster's own chance of this, stated with the estimate: 10%; the middle value does not contradict the limit.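

Compound 3 sits at a limit of this assay, which is not a number: the limit of > 10000 nM in this assay, at which 1 of the 3 values shown sits.
Ethoxy to isopropoxy therefore gives only a floor, an at least 1.2-fold higher number from compound 2 to compound 3 (0.10 log units; that floor lies within the scatter) and this change is not sized by it. Against methyl, isopropoxy gives an at least 7.5-fold higher number from compound 1 to compound 3 (0.87 log units; beyond the scatter) and so, on this aromatic carbon, both ethoxy and isopropoxy stand with higher numbers than methyl.

Going by these compounds, how far isopropoxy really lies from ethoxy stays open. Also open, on these data alone, is how hydrogen, a primary amine or a carboxylic acid would read on this aromatic carbon.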